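This account rests on a few compounds, and the source may have more. Where it says the series, first, only, none or still open, it means among the compounds named here.

Among the three compounds measured in a functional assay on BT-549 cells (Homo sapiens) for inhibition, read by sulforhodamine B assay, with a stated time of 48 h (a lower number here means that less compound is tolerated, a higher number that more compound is tolerated), compound 2 `COc1cc(-c2cc(/C=C/C(=O)c3ccc(N)cc3)[nH]n2)cc(OC)c1OC` gives the lowest number, 5760 nM. Compound 1 `COc1ccc(-c2cc(/C=C/C(=O)c3ccc(N)cc3)[nH]n2)cc1` gives 36300 nM, and compound 3 `COc1cc(-c2cc(/C=C/C(=O)c3ccc(Cl)c(Cl)c3)[nH]n2)cc(OC)c1OC` gives 92600 nM. For the measured compounds named here, the only single change measured is a 16-fold higher number from compound 2 to compound 3 (1.21 log units; beyond the scatter), and it concerns the other end of the shared core. Compound 4 `COc1ccc(-c2cc(/C=C/C(=O)c3ccc(N)cc3)[nH]n2)cc1OC` differs from compound 2 by hydrogen in place of methoxy on an aromatic carbon. Going by the values given here, no measured step matches this change; the nearest guide is that compound 1, which carries only one methoxy group on that ring, gives a clearly higher number than compound 2. Taking away one methoxy group is therefore expected to raise the number part of the way. The expected step is a 2.1-fold higher number from compound 2 to compound 4 (0.32 log units; beyond the scatter). Compound 4 is estimated at 12000 nM, within 4000 nM to 40000 nM.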

Compound 4, concentration lethal to 50% of the cells: 5770 nM
Beside the measured number, compound 4's estimate is 2.1-fold (0.32 log units) above it; the range from low to high includes it.
By their numbers in this assay, from the lowest: compounds 2 and 4 (each within the scatter of the next); then compound 1; then compound 3.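

Hydrogen in place of methoxy on this aromatic carbon gives a 1.0-fold higher number from compound 2 to compound 4 (0.00 log units; within the scatter) in this assay, so the two compounds cannot be told apart and the third methoxy group makes no readable difference here. The second methoxy group does make one: methoxy in place of hydrogen gives a 6.3-fold lower number from compound 1 to compound 4 (0.80 log units; beyond the scatter). Nothing shown gives a reason for either step.

Going by these compounds, whether a hydroxy group, an ethoxy group or a fluorine atom at this position would match hydrogen or methoxy remains open. So does whether this methoxy group would matter as little alongside the 3,4-dichlorophenyl group of compound 3.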